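The compounds below may be only part of what the source reports. "The series", "measured", "known", "first", "only" and "open" are said of these compounds alone.

Working notes on the series. For the measured compounds named here, in a functional assay on A549 cells (Homo sapiens) for inhibition, read by MTT assay, with a stated time of 24 h (a higher number here means a weaker inhibitor, a lower number a stronger inhibitor), compound 1 (`COc1ccc(Cc2nc(-c3cc(Br)c(OCCCN(C)C)c(Br)c3)cnc2Cl)cc1Br`) gives 14400 nM and is the lower of the two numbers so far. Compound 2 (`COc1ccc(Cc2nc(-c3cc(Br)c(O)c(Br)c3)c[nH]c2=O)cc1Br`) gives 52000 nM and so stands higher, beyond the scatter.

Next for measurement is compound 3 (`COc1ccc(Cc2nc(-c3cc(Br)c(O)c(Br)c3)cnc2Cl)cc1Br`). Its change from compound 1 is hydrogen in place of 3-(dimethylamino)propyl on an oxygen on an aromatic ring, which cuts back to hydroxy. Going by the values given here, no measured pair shows this change on its own, so the size of the step is a judgement resting on two values only. In this assay a moderate move toward a higher number is expected, probably beyond the scatter but not certainly so. The expected size is given by the estimated 2.1-fold higher number from compound 1 to compound 3 (0.32 log units; beyond the scatter) here. For compound 3 the estimate is 30000 nM, with an expected range of 12000 nM to 75000 nM.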

Compound 3, half-maximal inhibitory concentration: 41200 nM
The estimate for compound 3 lay 1.4-fold (0.14 log units) below the measured number, and the stated range covers the measured number.
By their numbers in this assay, from the lowest: compound 1; then compounds 3 and 2 (each within the scatter of the next).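

In this assay, for the compounds shown here, the cut from 3-(dimethylamino)propoxy to hydroxy on the aromatic ring gives a 2.9-fold higher number from compound 1 to compound 3 (0.46 log units; beyond the scatter) and is the first single-place reading at this oxygen. On this core, the 3-(dimethylamino)propyl group therefore goes with the lower number, by a modest step that exceeds the scatter, and the free hydroxy form does not match it. No measured property in the series bears on this step, so what lies behind it remains unknown.

This single pair does not separate the contribution of the propyl chain from that of its dimethylamino end. A plain propyl ether, a methyl ether, a shorter 2-(dimethylamino)ethyl chain or a chain ending in a morpholine or a carboxylic acid would be needed to tell which part of the group carries the step.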